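The source may report more compounds than this note shows. Statements on the series, on what has been measured and on what is new or still open speak of the compounds shown alone.

Measured compounds:
- compound 1 `CN(C)CCCCn1c2c(c3ccccc31)C(=O)c1c[n+]([O-])c3ccccc3c1C2=O`: 450 nM
- compound 2 `CC1(C)OC[C@H](Cn2cc(Cn3c4c(c5ccccc53)C(=O)c3c[n+]([O-])c5ccccc5c3C4=O)nn2)O1`: 130 nM
- compound 3 `O=C1c2c[n+]([O-])c3ccccc3c2C(=O)c2c1c1ccccc1n2Cc1cn([C@@H]2O[C@H](CO)[C@@H](O)[C@H](O)[C@H]2O)nn1`: 130 nM

In a functional assay on HCT-116 cells (Homo sapiens) for cytotoxicity, read by MTT assay, with a stated time of 72 h (on this read-out lower numbers stand for stronger inhibition and higher numbers for weaker inhibition), compound 1 gives the highest number of the three; compound 2 and compound 3 both sit at lower numbers, beyond the scatter. Compound 4 `O=C1c2c[n+]([O-])c3ccccc3c2C(=O)c2c1c1ccccc1n2CCCN1CCC(O)CC1` differs from compound 1 by 4-hydroxypiperidin-1-yl in place of (dimethylamino)methyl on a saturated chain carbon, three bonds along the chain from an aromatic nitrogen. Going by the values given here, the one measured step, no change at the digits printed from compound 2 to compound 3 (within the scatter), concerns a substituent on an aromatic nitrogen and lay within the scatter, so it says nothing about this change at the chain end. Among the compounds with values here, no measured step bears on it. Compound 4 is therefore expected to stay near compound 1, with a step of a 1.1-fold lower number from compound 1 to compound 4 (0.05 log units; within the scatter) that may not exceed the scatter. The estimate for compound 4 in this assay is 400 nM, within 150 nM to 1200 nM.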

Compound 4, half-maximal inhibitory concentration: 190 nM
Estimate against measurement, compound 4: 2.1-fold (0.32 log units) above, within the range that was stated.
By their numbers in this assay, from the lowest: compounds 2, 3 and 4 (each within the scatter of the next); then compound 1.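

In this assay the chain end proves sensitive to this exchange: the change to 3-(4-hydroxypiperidin-1-yl)propyl from 4-(dimethylamino)butyl gives a 2.4-fold lower number from compound 1 to compound 4 (0.37 log units; beyond the scatter) as a modest step, the first measured at this position. Going by these compounds alone, the single step alters the ring, the hydroxyl and the chain together, so their shares cannot be separated. Nothing measured explains the step. Still open, on these data alone, is whether piperidin-1-yl without the hydroxyl, or morpholin-4-yl, would give a similar number on the same chain. Also open, as far as these compounds go, is how 4-hydroxypiperidin-1-yl would behave on a butyl or ethyl chain.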